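Urea aryl variation: estimate for compound 3

The source may hold more compounds than are shown below. What is called first, only, known or untested is meant among the compounds shown, and "the series" means these compounds.

For the measured compounds named here, compound 2 `COc1cc2cc(Oc3ccc(NC(=O)Nc4cccc(C(F)(F)F)c4)cc3)c(C)nc2cc1OC` holds the lower of the two numbers so far in a functional assay on SK-MEL-2 cells (Homo sapiens) for inhibition, read by sulforhodamine B assay, with a stated time of 48 h, tested at 10 uM; on this read-out higher numbers stand for a weaker effect at the one concentration tested and lower numbers for a stronger effect: compound 2 gives -35.8%, whereas compound 1 `COc1cc2cc(Oc3ccc(NC(=O)Nc4ccccc4)cc3)c(C)nc2cc1OC` gives 78.8%. Going by the values given here, the single measured step is a number 114.6 percentage points lower from compound 1 to compound 2 (beyond the scatter), a large drop in the read-out on adding trifluoromethyl to the terminal phenyl of the urea. Compound 3 `COc1cc2cc(Oc3ccc(NC(=O)Nc4ccc(Cl)c(Cl)c4)cc3)c(C)nc2cc1OC` differs from compound 2 by 3,4-dichlorophenyl in place of 3-(trifluoromethyl)phenyl on an amide-type nitrogen. The measured step bears on this only indirectly: it shows that a substituted phenyl at this nitrogen gives a far stronger effect than the unsubstituted one, but no measurement compares two differently substituted phenyls. Compound 3 is expected to remain close to compound 2, with a number 15.8 percentage points higher from compound 2 to compound 3 (beyond the scatter) expected to fall within the scatter, because compound 2 with -35.8% already sits far below the unsubstituted compound 1. Compound 3 is therefore estimated at -20%, within -60% to 30%.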

Compound 3, a percentage reported as activity, at one concentration (the size of the read-out at that concentration, not a potency): -7.82%
Compound 3: the middle estimate sits 12.2 percentage points below what was measured; measured number inside the range.
By their numbers in this assay, from the lowest: compound 2; then compound 3; then compound 1.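

In this assay the phenyl on the amide-type nitrogen now has a second substituted example, and the series shows a number 86.6 percentage points lower from compound 1 to compound 3 (beyond the scatter) so the large drop is not confined to trifluoromethyl. The two substituted groups do not give the same result: the replacement gives a number 28 percentage points higher from compound 2 to compound 3 (beyond the scatter) and 3-(trifluoromethyl)phenyl keeps the lowest number of the three compounds. Nothing available here accounts for either step.

Open is which feature of the substituents matters: 3,4-dichlorophenyl differs from 3-(trifluoromethyl)phenyl in both the kind and the number of substituents, and no compound shown separates the two. Also open, on these data alone, is how the read-out responds to an amine or a carboxylic acid on this phenyl, or to a longer alkyl chain in its place.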